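The source may report more compounds than this note shows. Statements on the series, on what has been measured and on what is new or still open speak of the compounds shown alone.

In a functional assay on A549 cells (Homo sapiens) for antiproliferative activity, read by MTT assay, with a stated time of 72 h (on this read-out lower numbers stand for stronger inhibition and higher numbers for weaker inhibition), compound 1 `COc1cccc(N2C(=O)COc3ccc(-c4cccc(NS(=O)(=O)c5ccc(F)cc5)c4)cc32)c1` reads > 40000 nM and this value is a limit of the assay. Within the data shown here, compound 2 `O=C1COc2ccc(-c3cccc(NS(=O)(=O)c4ccc(F)cc4)c3)cc2N1c1ccc(Cl)cc1` gives 31600 nM as the only number so far. Compound 3 `O=C1COc2ccc(-c3cccc(NS(=O)(=O)c4ccc(F)cc4)c3)cc2N1c1ccccc1` has hydrogen in place of chloro on an aromatic carbon, para to a large group (hydrogen in place of chloro on an aromatic carbon). Among the measured compounds shown here, the one measured step of an at least 1.2-fold lower number from compound 1 to compound 2 (0.10 log units; that floor lies within the scatter) changes the same aryl group and stays within the scatter. Its starting point is the limit of > 40000 nM in this assay, at which 1 of the 2 values shown sits, and it gives only a floor. In this assay the expected 1.1-fold lower number from compound 2 to compound 3 (0.02 log units; within the scatter) is no larger than the scatter. Compound 3 is estimated at 30000 nM (expected range 12000 nM to 60000 nM).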

Compound 3, half-maximal inhibitory concentration: > 40000 nM
Compound 3: no number, only a limit; the forecaster's own chance of this, stated with the estimate: 45%; at least 1.3-fold (0.12 log units) between middle value and limit.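

Taking the chloro off the 4-chlorophenyl group gives an at least 1.2-fold higher number from compound 2 to compound 3 (0.10 log units; that floor lies within the scatter) in this assay, so a contribution from chloro at this position is neither shown nor excluded. Compound 3 reads > 40000 nM, which is a limit, and the step between the two limit compounds cannot be read. The aryl comparison now rests mostly on such limits: the limit of > 40000 nM in this assay, at which 2 of the 3 values shown sit.

On these data alone, whether an amine or a carboxylic acid on this phenyl ring would give a clear number remains open. So does the effect of a longer chain in place of the ring.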